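Dropping the Methylsulfanyl from a Thiol Nucleoside

The source may hold more compounds than are shown below. What is called first, only, known or untested is meant among the compounds shown, and "the series" means these compounds.

Measured so far:
compound 1 `CSS[C@H]1C(O)[C@@H](CO)O[C@H]1n1ccc(=O)[nH]c1=O` gives > 650000 nM
compound 2 `CSS[C@H]1C(O)[C@@H](CO)O[C@H]1n1ccc(N)nc1=O` gives > 650000 nM

In a functional assay on FM3A cells (Mus musculus) for antiproliferative activity (a higher number here means a weaker inhibitor, a lower number a stronger inhibitor), compound 1 reaches only a limit of the assay, > 650000 nM. In this assay compound 2 likewise gives only a limit, > 650000 nM, so it stands at the limit of > 650000 nM in this assay, at which 2 of the 2 values shown sit, and no actual number is known for it. Compound 3 `Nc1ccn([C@@H]2O[C@H](CO)C(O)[C@@H]2S)c(=O)n1` arises from compound 2 by hydrogen in place of methylsulfanyl on a sulfur. For the measured compounds named here, no measured pair shows a comparable change, so nothing points to a direction; the step of a number no higher from compound 2 to compound 3 (the limit leaves the size open) is expected to stay within the scatter. Compound 3 is therefore estimated at 650000 nM, between 100000 nM and 2000000 nM, most probably again only a limit.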

Compound 3, half-maximal inhibitory concentration: > 675000 nM
Compound 3: no number, only a limit; the forecaster's own chance of this, stated with the estimate: 75%; middle value at least 1.0-fold (0.01 log units) from the limit.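

In this assay compound 3 gives > 675000 nM, which is a limit. For the compounds shown here, compound 2 gives > 650000 nM, also a limit, so no step between compound 2 and compound 3 can be read. The compounds shown leave open whether hydrogen in place of methylsulfanyl on a sulfur changes the activity at all.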